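Replacing benzamido on the shared core: clearance notes

The source may hold more compounds than are shown below. What is called first, only, known or untested is meant among the compounds shown, and "the series" means these compounds.

Measured so far in an ADME assay on microsomes from liver (Homo sapiens) for metabolic stability, read by LC-MS, using NADPH, with stated times of 5 min and 30 min, tested at 1 uM (a higher number here means faster removal of the compound, a lower number slower removal), for two compounds:
- compound 1 (`COCCC(=O)Nc1cnc(NCc2c(F)ccc3c2CCO3)n2cnnc12`): < 3 mL.min-1.g-1
- compound 2 (`O=C(Nc1cnc(NCc2c(F)ccc3c2CCO3)n2cnnc12)c1ccccc1`): 10 mL.min-1.g-1

The entry for compound 1 is a limit of the assay and not a number. For the measured compounds named here, compound 2 holds the only number so far at 10 mL.min-1.g-1 in these notes. The change to compound 3 (`O=C1CC2(CC2)CN1c1cnc(NCc2c(F)ccc3c2CCO3)n2cnnc12`) is a group of 8 heavy atoms (6 carbon, 1 nitrogen, 1 oxygen; one three-membered non-aromatic ring of carbon only, one five-membered non-aromatic ring with 1 hetero atom) in place of a group of 9 heavy atoms (7 carbon, 1 nitrogen, 1 oxygen; one six-membered aromatic ring of carbon only), on an aromatic carbon on an aromatic carbon. Going by the values given here, one measured step bears on it: an at least 3.3-fold higher number from compound 1 to compound 2 (0.52 log units; beyond the scatter) came with the arrival of a phenyl, and compound 3 has no six-membered aromatic ring of carbon only at this place. A modest move towards slower removal is therefore expected in this assay and the expected step is a 2.0-fold lower number from compound 2 to compound 3 (0.30 log units; within the scatter) on this reasoning. Compound 3 is estimated at 5 mL.min-1.g-1 with an expected range of 3 mL.min-1.g-1 to 12 mL.min-1.g-1 in this read-out.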

Compound 3, intrinsic clearance in microsomes: < 3 mL.min-1.g-1
Compound 3: a limit, no number; the forecaster's own chance of this, stated with the estimate: 25%; middle value at least 1.6-fold (0.22 log units) away from the limit.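

In this assay the change from benzamido to the spiro-fused ring group gives an at least 3.3-fold lower number from compound 2 to compound 3 (0.52 log units; beyond the scatter), so a ring at this place does not in itself bring the faster removal seen with compound 2. The entry for compound 3, < 3 mL.min-1.g-1, is a limit of the assay and not a number. The step between compound 1 and compound 3 cannot be read, and the two cannot be ordered: the limit of < 3 mL.min-1.g-1 in this assay, at which 2 of the 3 values shown sit.

From the compounds shown here alone, how far removal falls under that limit stays open. Also open, going by these compounds, is whether a cyclohexyl on the same carbonyl, or a simple amine at this place, would stay there.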